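Removing the fluoro group: compound 3 to compound 4

The source may report more compounds than this note shows. Statements on the series, on what has been measured and on what is new or still open speak of the compounds shown alone.

Compounds measured so far:
- compound 1, `Cc1cc(C)cc(S(=O)(=O)c2c(C(=O)NCc3ccccc3)[nH]c3ccc(Cl)c(F)c23)c1`: 15000 nM
- compound 2, `Cc1cc(C)cc(S(=O)(=O)c2c(C(=O)NCN3CCCCC3)[nH]c3ccc(Cl)cc23)c1`: 9900 nM
- compound 3, `Cc1cc(C)cc(S(=O)(=O)c2c(C(=O)NCCOc3ccccc3)[nH]c3ccc(Cl)c(F)c23)c1`: 11000 nM

In an ADME assay on CCRF-CEM cells (Homo sapiens) for cytotoxicity, read by cell counting (on this read-out higher numbers stand for lower toxicity in this test and lower numbers for higher toxicity in this test), compound 3 stands second highest of the three numbers; its nearest neighbour is compound 2 and its furthest is compound 1, and in both cases the gap lies within the scatter. Compound 4, `Cc1cc(C)cc(S(=O)(=O)c2c(C(=O)NCCOc3ccccc3)[nH]c3ccc(Cl)cc23)c1`, differs from compound 3 by hydrogen in place of fluoro on an aromatic carbon. Among the measured compounds shown here, the only measured step, a 1.4-fold lower number from compound 1 to compound 3 (0.13 log units; within the scatter), concerns a change on the chain, not this position, so no step bears directly on it. Compound 2 and compound 3 differ in two places and show values within the scatter of each other. The account therefore expects no step beyond the scatter, a 1.1-fold lower number from compound 3 to compound 4 (0.04 log units; within the scatter). The estimate for compound 4 in this assay is 10000 nM, in the range 5000 nM to 20000 nM.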

Compound 4, half-maximal cytotoxic concentration: 207000 nM
Compound 4: middle estimate off by 21-fold (1.32 log units), on the low side, and the stated range ends below it.
By their numbers in this assay, from the lowest: compounds 2, 3 and 1 (each within the scatter of the next); then compound 4.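

In this assay, among the compounds shown here, this position proves decisive: hydrogen in place of the fluoro group on the aromatic carbon ortho to a chloro group gives a large step (a 19-fold higher number from compound 3 to compound 4 (1.27 log units; beyond the scatter)), which the earlier compounds, all within the scatter of each other, did not foreshadow. With hydrogen there, the chain also counts: phenoxymethyl in place of piperidin-1-yl gives a large step too (a 21-fold higher number from compound 2 to compound 4 (1.32 log units; beyond the scatter)). Nothing available explains either step. From the compounds shown here alone, whether hydrogen in place of fluoro acts alike in compound 1 stays open, as does what a methoxy or bromo group would give at this position.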